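Quaternary substituent at the lactone ring carbon: hydroxy variant

This account rests on a few compounds, and the source may have more. Where it says the series, first, only, none or still open, it means among the compounds named here.

Measured so far in a functional assay on B16 cells (Mus musculus) for cytotoxicity, read by MTT assay; a higher number here means a weaker inhibitor, a lower number a stronger inhibitor:
compound 1 `CC(=O)O[C@@H]1OC(=O)[C@](C)(C(C)=O)[C@@H]1C`, 4000 nM
compound 2 `CC(=O)O[C@@H]1OC(=O)[C@](Cc2ccccc2)(C(C)=O)[C@@H]1C`, 41000 nM
compound 3 `CC(=O)CC[C@]1(C(C)=O)C(=O)O[C@@H](OC(C)=O)[C@H]1C`, 7000 nM

Compound 3 sits second highest of the three; its nearest neighbour is compound 1, a 1.8-fold higher number from compound 1 to compound 3 (0.24 log units; within the scatter), while compound 2 lies furthest, a 5.9-fold lower number from compound 2 to compound 3 (0.77 log units; beyond the scatter). Compound 4 `CC(=O)O[C@@H]1OC(=O)[C@](O)(C(C)=O)[C@@H]1C` differs from compound 3 at the same ring carbon: hydroxy in place of 2-acetylethyl on a saturated ring carbon. All three measured steps bear on this position. Enlarging the group gave a 10-fold higher number from compound 1 to compound 2 (1.01 log units; beyond the scatter); the chain in compound 3 gave only a 1.8-fold higher number from compound 1 to compound 3 (0.24 log units; within the scatter). A one-atom group is closer to the hydrogen of compound 1 than to either chain, so compound 4 is expected to land near compound 1 with a 1.4-fold lower number from compound 3 to compound 4 (0.15 log units; within the scatter), within the scatter. Compound 4 is estimated at 5000 nM, range 1500 nM to 17000 nM.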

Compound 4, half-maximal inhibitory concentration: > 50000 nM
Compound 4: no number, only a limit; the forecaster's own chance of this, stated with the estimate: 5%; middle value at least 10-fold (1.00 log units) away from the limit.
By their numbers in this assay, from the lowest: compounds 1 and 3 (each within the scatter of the next); then compound 2. At a limit, above all of these: compound 4.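

In this assay compound 4 gives only a limit, not a number: the limit of > 50000 nM in this assay, at which 1 of the 4 values shown sits. A small group at this ring carbon therefore does not stay close to methyl, with hydroxy giving an at least 12-fold higher number from compound 1 to compound 4 (1.09 log units; beyond the scatter) and, against the 2-acetylethyl chain, an at least 7.1-fold higher number from compound 3 to compound 4 (0.85 log units; beyond the scatter), so size alone does not order the series. Against benzyl the reading is an at least 1.2-fold higher number from compound 2 to compound 4 (0.08 log units; that floor lies within the scatter), which leaves the order of these two compounds unsettled.

Open, going by these compounds, is whether a methoxy group or an amine at this ring carbon stays with compound 1 or follows compound 4.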